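This account rests on a few compounds, and the source may have more. Where it says the series, first, only, none or still open, it means among the compounds named here.

The compounds share one core, a dimethoxy-substituted bicyclic scaffold, with the trial read in a functional assay on HepG2 cells (Homo sapiens) for antiproliferative activity, with a stated time of 72 h; on this read-out lower numbers stand for an effect already at smaller amounts and higher numbers for an effect only at larger amounts of compound.

Compound 1, `COc1ccc(-c2cc(=O)c3c(OC)cc(OC)cc3n2S(=O)(=O)c2ccc(OC)cc2)cc1`, carries a sulfonyl group on the ring nitrogen and an aryl substituent on the pyranone carbon. In this assay compound 1 gives > 82700 nM, which is a limit of the assay and not a number, as the limit of > 82700 nM in this assay, at which 1 of the 2 values shown sits, records.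

Compound 2, `COc1cc(OC)c2c(=O)cc(C(=O)Nc3ccc(C4CCCCC4)cc3)[nH]c2c1`, instead bears a carboxamide to an aniline carrying a cyclohexyl group. In this assay compound 2 gives > 43100 nM, again a limit of the assay and not a number, the value at the limit of > 43100 nM in this assay, at which 1 of the 2 values shown sits. For the measured compounds named here, compound 2 therefore stands at the limit with no measured number of its own, and no step between compound 1 and compound 2 can be sized from two limits.

Compound 3, `COc1cc(OC)c2c(=O)cc(C(=O)Nc3ccc(Oc4ccc(F)cc4)cc3)[nH]c2c1`, keeps the carboxamide and differs from compound 2 by 4-fluorophenoxy in place of cyclohexyl on an aromatic carbon. Since both neighbours sit at limits, the step from compound 2 to compound 3 is expected to be none beyond the scatter, or small in either direction; it is expected as a step that the limit leaves unreadable from compound 2 to compound 3. Compound 3 is estimated at 45000 nM, expected to fall between 12000 nM and 150000 nM, with a substantial chance that only a limit is again reported.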

Compound 3, half-maximal effective concentration: > 50000 nM
Compound 3 gave a limit, no number (the forecaster's own chance of this, stated with the estimate: 65%); at least 1.1-fold (0.04 log units) between middle value and limit.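

Compound 2 and compound 3 both end at limits of the assay and not at numbers, so the size of the change from cyclohexyl to 4-fluorophenoxy on an aromatic carbon cannot be read. The compounds shown leave open whether any substituent on the shared core gives a measured number in this assay.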